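This account rests on a few compounds, and the source may have more. Where it says the series, first, only, none or still open, it means among the compounds named here.

Measured compounds in a functional assay on HCT-15 cells (Homo sapiens) for inhibition, read by sulforhodamine B assay, with a stated time of 48 h; a higher number here means a weaker inhibitor of growth, a lower number a stronger inhibitor of growth:
compound 1 `COc1cc(-c2cc(/C=C/C(=O)c3ccc(N)cc3)[nH]n2)cc(OC)c1OC` gives 6760 nM
compound 2 `COc1ccc(C(=O)/C=C/c2cc(-c3cc(OC)c(OC)c(OC)c3)n[nH]2)cc1OC` gives 2850 nM
compound 3 `COc1ccc(-c2cc(/C=C/C(=O)c3ccc(N)cc3)[nH]n2)cc1OC` gives 5370 nM

Compound 2 carries the lowest number of the three in this assay; its gap to compound 3 lies within the scatter, and the step of a 2.4-fold lower number from compound 1 to compound 2 (0.38 log units; beyond the scatter) is the only one here beyond it. How the cores of compound 2 and compound 3 differ is not broken down here.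

The change from compound 3 to compound 1 is methoxy in place of hydrogen on an aromatic carbon. That step, a 1.3-fold higher number from compound 3 to compound 1 (0.10 log units; within the scatter), stays within the scatter, so the added methoxy changed little there.

Compound 4 `COc1cc(C(=O)/C=C/c2cc(-c3cc(OC)c(OC)c(OC)c3)n[nH]2)cc(OC)c1OC` is not yet measured in this assay. It differs from compound 2 by methoxy in place of hydrogen on an aromatic carbon, the same kind of change as from compound 3 to compound 1, made on the same kind of place. Resting on compound 1 and compound 3 and their step of a 1.3-fold higher number from compound 3 to compound 1 (0.10 log units; within the scatter), a step of a 1.2-fold higher number from compound 2 to compound 4 (0.08 log units; within the scatter) from compound 2 to compound 4 is expected, again within the scatter. Compound 4 is therefore estimated at 3400 nM, with a range from 1500 nM to 8000 nM.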

Compound 4, concentration for total growth inhibition: 3290 nM
Estimate against measurement, compound 4: 1.0-fold (0.01 log units) above; the range from low to high includes it.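

The new step in this assay is a 1.2-fold higher number from compound 2 to compound 4 (0.06 log units; within the scatter) and so, as on the core of compound 1, methoxy in place of hydrogen on an aromatic carbon changes little on the core of compound 4. The change reads alike on both cores, with the two steps agreeing within the scatter: the same change on two cores in this assay, a 1.3-fold higher number (0.10 log units; within the scatter) from compound 3 to compound 1 and a 1.2-fold higher number (0.06 log units; within the scatter) from compound 2 to compound 4, 1.1-fold (0.04 log units) apart, within the scatter of two such steps

This shows that a small effect carries across these two cores, but with both steps within the scatter it gives no direction for the change and says nothing about cores beyond these two.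

Methoxy is the only group shown entering at this place, so the effect of a hydroxy group, a fluorine atom, an amine or a longer chain such as ethoxy remains open. On these data alone, the replacement of 4-aminophenyl by 3,4-dimethoxyphenyl on the carbonyl carbon, seen in a 2.4-fold lower number from compound 1 to compound 2 (0.38 log units; beyond the scatter) and beyond the scatter, rests on that single pair, and whether it carries to another core also remains open.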